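This account rests on a few compounds, and the source may have more. Where it says the series, first, only, none or still open, it means among the compounds named here.

Measured in a functional assay on HepG2 cells (Homo sapiens) for inhibition, read by MTT assay, with a stated time of 72 h; on this read-out lower numbers stand for stronger inhibition and higher numbers for weaker inhibition:
- compound 1 `CNC(=O)CCCCCCCn1nc(-c2cnc3[nH]ccc3c2)c2c(N)ncnc21`: 5630 nM
- compound 2 `Nc1ncnc2c1c(-c1cnc3[nH]ccc3c1)nn2CCCCCCCCCC(=O)NO`: 11700 nM
- compound 3 `Nc1nc2cc(-c3nn(CCC(=O)NO)c4ncnc(N)c34)ccc2o1`: > 150000 nM (a limit of the assay)

Compound 1 stands lowest of the two actual numbers in this assay. Among the compounds with values here, the only measured step is a 2.1-fold higher number from compound 1 to compound 2 (0.32 log units; beyond the scatter), with 2-(hydroxycarbamoyl)ethyl in place of methylcarbamoyl, and it is modest.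

Compound 4 `Nc1ncnc2c1c(-c1cnc3[nH]ccc3c1)nn2CCC(=O)NO` keeps the core of compound 1 but changes the side chain: hydroxycarbamoyl in place of 5-(methylcarbamoyl)pentyl on a saturated chain carbon, two bonds along the chain from an aromatic nitrogen. Hydroxycarbamoyl replaces 5-(methylcarbamoyl)pentyl on a saturated chain carbon, two bonds along the chain from an aromatic nitrogen. The measured step brings in the same end group, but on a longer chain, so it bears on this change only in part. Compound 3 also holds hydroxycarbamoyl at that place, and its reading is only a limit, > 150000 nM.

The expected step in this assay therefore runs towards a higher number, and it is estimated to be larger than the one seen so far: an 11-fold higher number from compound 1 to compound 4 (1.03 log units; beyond the scatter). Compound 4 is estimated at 60000 nM, with an expected range of 15000 nM to 150000 nM.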

Compound 4, half-maximal inhibitory concentration: > 150000 nM
Compound 4: no number, only a limit; the forecaster's own chance of this, stated with the estimate: 35%; middle value at least 2.5-fold (0.39 log units) from the limit.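

In this assay compound 4 gives > 150000 nM, which is a limit of the assay and not a number. At this place, the change to hydroxycarbamoyl brings an at least 26-fold higher number from compound 1 to compound 4 (1.42 log units; beyond the scatter), a large step, whereas the earlier step on the long chains was only modest, and compound 2, with the same end group on a longer chain, still reads 11700 nM. Compound 3, which holds the same short side chain on a changed core, sits at the same limit, so a short chain ending in hydroxycarbamoyl has now reached it on both cores: the limit of > 150000 nM in this assay, at which 2 of the 4 values shown sit.

How far compound 3 and compound 4 lie past that limit, or how they differ, cannot be read. From the compounds shown here alone, it also stays open whether the shorter chain or the end group carries the change, which a short chain ending in methylcarbamoyl, or a chain of intermediate length ending in hydroxycarbamoyl or a carboxylic acid, would separate.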